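The source may report more compounds than this note shows. Statements on the series, on what has been measured and on what is new or still open speak of the compounds shown alone.

Measured in a toxicity assay on HUVEC cells (Homo sapiens) for inhibition; a higher number here means a weaker inhibitor of growth, a lower number a stronger inhibitor of growth:
compound 1 `Cc1nc(-c2ccccc2)c(C(=O)N2CCN(c3cccc(C)c3C)CC2)o1`: 0.38 ug/mL
compound 2 `Cc1nc(-c2ccccc2)c(C(=O)N2CCN(c3cc(Cl)cc(Cl)c3)CC2)o1`: 0.191 ug/mL

Within the data shown here, the only measured step is a 2.0-fold lower number from compound 1 to compound 2 (0.30 log units; within the scatter). Among the measured compounds shown here, compound 2, at 0.191 ug/mL, therefore stands level with the one other measured compound, and the two cannot be ranked.

The next compound is compound 3 `COc1cc(OC)cc(N2CCN(C(=O)c3oc(C)nc3-c3ccccc3)CC2)c1`, which keeps the core of compound 2 and has 3,5-dimethoxyphenyl in place of 3,5-dichlorophenyl on an amine nitrogen in a ring.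

For the measured compounds named here, the one measured step bears on this change only in part. It altered the group at the same place, and its size, a 2.0-fold lower number from compound 1 to compound 2 (0.30 log units; within the scatter), did not exceed the scatter. Going by the values given here, no measured compound carries a methoxy group, so the direction of any change in this assay is open, and a single step is thin evidence. No shift beyond the scatter is expected. The estimated step is a 1.5-fold higher number from compound 2 to compound 3 (0.17 log units; within the scatter), which is not expected to be distinguishable from no change. For compound 3 the expected value is 0.28 ug/mL, with an estimated range of 0.1 ug/mL to 0.8 ug/mL.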

Compound 3, concentration for 50% growth inhibition: 0.319 ug/mL
Beside the measured number, compound 3's estimate is 1.1-fold (0.06 log units) below it; measured number inside the range.
By their numbers in this assay, from the lowest: compounds 2, 3 and 1 (each within the scatter of the next).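

In this assay, 3,5-dimethoxyphenyl in place of 3,5-dichlorophenyl on the amine nitrogen gives a 1.7-fold higher number from compound 2 to compound 3 (0.22 log units; within the scatter), so a group carrying hydrogen-bond acceptors takes the place of one with none, with two more heavy atoms, and the step stays within the scatter. The comparison with the other aryl group reads the same way, with a 1.2-fold lower number from compound 1 to compound 3 (0.08 log units; within the scatter), so 2,3-dimethylphenyl, 3,5-dichlorophenyl and 3,5-dimethoxyphenyl cannot be told apart at this position, and the three compounds form one level group with no ranking among them. No supporting measurement bears on this result, so the flat reading stands as an observation only.

Whether this position tolerates every substituent equally remains open, since all three compounds shown carry neutral carbon, chlorine or oxygen substituents on the phenyl ring; an amine or a carboxylic acid on that ring, or a longer alkoxy chain in place of methoxy, would test whether the number can move beyond the scatter at all. The shared core is also constant throughout, so nothing shown says how the rest of the molecule contributes to the growth inhibition seen here.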